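Shortening the Alkoxy Chain of a Chloroquinoline Cytotoxin

A few compounds are considered here, and "the series" means these few. Any claim that something is new, unique, unknown or untested is made for them only; others in the source may bear on it.

Compound 1 `CCCCCCOc1ccc2c(Cl)ccnc2c1` gives 2420 nM in a functional assay on HepG2 cells (Homo sapiens) for cytotoxicity, read by MTT assay, with a stated time of 48 h (on this read-out higher numbers stand for weaker inhibition and lower numbers for stronger inhibition), the highest of the two numbers measured; its nearest neighbour, compound 2 `CCCCCCOc1ccc2c(NCCN(C)C)ccnc2c1`, gives 1370 nM, and a 1.8-fold lower number from compound 1 to compound 2 (0.25 log units; within the scatter). Compound 3 `CCCCOc1ccc2c(Cl)ccnc2c1` differs from compound 1 only on the side chain: hydrogen in place of ethyl on a saturated chain carbon, four bonds along the chain from an oxygen on an aromatic ring. Within the data shown here, no measured step touches this chain, since the one step seen concerns the (2-(dimethylamino)ethyl)amino group in place of chloro, and that step itself stayed within the scatter. The author therefore expects no step beyond the scatter, a 1.2-fold higher number from compound 1 to compound 3 (0.09 log units; within the scatter). Compound 3 is estimated at 3000 nM, within 1200 nM to 7500 nM.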

Compound 3, half-maximal inhibitory concentration: 2640 nM
Compound 3: the middle estimate sits 1.1-fold (0.06 log units) above what was measured, and the stated range covers the measured number.
By their numbers in this assay, from the lowest: compounds 2, 1 and 3 (each within the scatter of the next).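

Replacing ethyl with hydrogen on a saturated chain carbon, four bonds along the chain from an oxygen on an aromatic ring, is the only step shown that touches this chain. In this assay it gives a 1.1-fold higher number from compound 1 to compound 3 (0.04 log units; within the scatter), so with chloro on the core, this shortening leaves the number within the scatter. No evidence is available that bears on this result. On these data alone, it remains open whether an amine or a carboxylic acid at the end of the chain, or a longer chain, would move the number. As far as these compounds go, the same shortening also remains untested alongside (2-(dimethylamino)ethyl)amino in place of chloro.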